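Dichlorophenyl analogue expected to keep the halogen gain

A few compounds are considered here, and "the series" means these few. Any claim that something is new, unique, unknown or untested is made for them only; others in the source may bear on it.

In a functional assay on muscle tissue for agonist activity at histamine H2 receptor (Cavia porcellus) (a higher number here means a more potent compound, by a factor of ten per unit of this negative logarithm, a lower number a less potent compound), compound 1 `N=C(NCCCc1c[nH]cn1)NCCC(c1ccccc1)c1ccccn1` gives 7.37. Compound 2 `N=C(NCCCc1c[nH]cn1)NCCC(c1ccc(F)cc1)c1ccccn1` gives 7.94 in this assay, and compound 3 `N=C(NCCCc1c[nH]cn1)NCCC(c1cccc(F)c1)c1ccccn1` gives 7.79. Compound 3 thus stands second highest of the three numbers, nearest to compound 2 and furthest from compound 1. The change to compound 4 `N=C(NCCCc1c[nH]cn1)NCCC(c1ccc(Cl)c(Cl)c1)c1ccccn1` is 3,4-dichlorophenyl in place of 3-fluorophenyl on a saturated chain carbon bound to an aromatic carbon and a saturated chain carbon. Among the measured compounds shown here, the steps that bear on it are a number 0.57 log units higher from compound 1 to compound 2 (beyond the scatter) and a number 0.42 log units higher from compound 1 to compound 3 (beyond the scatter), both modest gains when fluoro replaced hydrogen on an aromatic carbon, while a number 0.15 log units lower from compound 2 to compound 3 (within the scatter) lies within the scatter. A further small gain, or a flat result, is therefore expected in this assay, as a number 0.11 log units higher from compound 3 to compound 4 (within the scatter). Compound 4 is estimated at 7.9, within 7.3 to 8.5.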

Compound 4, negative logarithm of the half-maximal effective concentration: 7.54
The estimate for compound 4 lay 0.36 log units above the measured number; low and high end bracket the measured number.
By their numbers in this assay, from the lowest: compounds 1, 4, 3 and 2 (each within the scatter of the next, the first and the last beyond it).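

At this position, 3,4-dichlorophenyl does not clearly keep the gain seen with a single fluoro: in this assay, the change reads a number 0.17 log units higher from compound 1 to compound 4 (within the scatter), and the comparison with the 3-fluorophenyl analogue reads a number 0.25 log units lower from compound 3 to compound 4 (within the scatter), both within the scatter. Only the comparison with the 4-fluorophenyl analogue, a number 0.40 log units lower from compound 2 to compound 4 (beyond the scatter), lies beyond it. Nothing measured here accounts for this result. The compounds shown leave open whether a single chlorine on the phenyl ring would match either fluoro compound, and how a methoxy or trifluoromethyl group would fare at this place.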